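A few compounds are considered here, and "the series" means these few. Any claim that something is new, unique, unknown or untested is made for them only; others in the source may bear on it.

Going by the values given here, compound 3 `CNS(=O)(=O)c1ccc(NC(=O)NCc2ccncc2)cc1` carries a methylamino group on the sulfonyl sulfur, and in an assay on isolated protein for activation of Nicotinamide phosphoribosyltransferase (Homo sapiens) (on this read-out higher numbers stand for an effect only at larger amounts of compound and lower numbers for an effect already at smaller amounts), compound 3 gives 3230 nM, the highest of the three numbers measured so far. Its closest neighbour is compound 1 `O=C(NCc1ccncc1)Nc1ccc(S(=O)(=O)Nc2ccccc2)cc1`, which in this assay gives 410 nM; the step of a 7.9-fold higher number from compound 1 to compound 3 (0.90 log units; beyond the scatter) shows what happens when the phenyl on the sulfonamide nitrogen is cut back to a methyl. Furthest away is compound 2 `O=C(NCc1ccncc1)Nc1ccc(S(=O)(=O)c2ccccc2Cl)cc1`, which gives 79 nM; the step of a 41-fold higher number from compound 2 to compound 3 (1.61 log units; beyond the scatter) shows the loss when a 2-chlorophenyl directly on the sulfur is replaced by methylamino, and the step of a 5.2-fold lower number from compound 1 to compound 2 (0.72 log units; beyond the scatter) shows the gain when that aromatic ring sits directly on the sulfur instead of through an amino linker.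

Compound 4 `O=C(NCc1ccncc1)Nc1ccc(S(=O)(=O)N2CCc3ccccc3C2)cc1` differs from compound 3 as follows: 1,2,3,4-tetrahydroisoquinolin-2-yl in place of methylamino on a sulfonyl sulfur. Like compound 2, compound 4 puts a ring system with an aromatic part directly on the sulfur and removes the hydrogen-bond donor that compound 3 and compound 1 carry. Both comparisons point the same way, toward a lower number, so a step of the order of a 13-fold lower number from compound 3 to compound 4 (1.11 log units; beyond the scatter) is expected for compound 4. The estimated value for compound 4 in this assay is 250 nM, with a range from 60 nM to 1000 nM.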

Compound 4, half-maximal effective concentration: 142 nM
The estimate for compound 4 lay 1.8-fold (0.25 log units) above the measured number, and the stated range covers the measured number.
By their numbers in this assay, from the lowest: compounds 2 and 4 (each within the scatter of the next); then compound 1; then compound 3.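

In this assay, exchanging the small methylamino group on the sulfonyl sulfur for the larger 1,2,3,4-tetrahydroisoquinolin-2-yl group gives a large gain (a 23-fold lower number from compound 3 to compound 4 (1.36 log units; beyond the scatter)), and the result sits level with the 2-chlorophenyl compound (a 1.8-fold higher number from compound 2 to compound 4 (0.25 log units; within the scatter)), which shows that a nitrogen attached to the sulfur does not by itself hold the number high. The comparison with the anilino group (a 2.9-fold lower number from compound 1 to compound 4 (0.46 log units; beyond the scatter)) adds that two groups with an aromatic ring and a nitrogen on the sulfur can still differ, the one with no hydrogen-bond donor giving the lower number. Nothing shown here explains why these steps have the sizes they do.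

Compound 4 changes the ring count, the size and the hydrogen-bond donor all at once, so these compounds cannot say which of those changes matters. A dimethylamino group would remove the donor while staying small, and a piperidin-1-yl group would keep a six-membered non-aromatic ring without the aromatic ring, so these two groups would begin to pull those effects apart.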